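Swapping Trifluoromethyl for Fluoro on a Hydrazone Antiproliferative

The compounds below may be only part of what the source reports. "The series", "measured", "known", "first", "only" and "open" are said of these compounds alone.

Compound 1 `COc1cc(C(=O)N/N=C/c2ccc(C(F)(F)F)cc2)cc(OC)c1OC` was tested in a functional assay on PC-3 cells (Homo sapiens) for antiproliferative activity, read by MTT assay, tested at 5 uM (on this read-out lower numbers stand for a weaker effect and higher numbers for a stronger effect at the one concentration tested), where compound 1 gives 61.6%. Among the two numbers available it is the lower one: compound 2 `COc1cc(C2=NN(C(C)=O)C(c3cc(Cl)cc(Cl)c3)O2)cc(OC)c1OC`, which is built on a different core, gives 93.9% in this assay, a gap that lies beyond the usual scatter of repeated measurements. Compound 3 `COc1cc(C(=O)N/N=C/c2ccc(F)cc2)cc(OC)c1OC` keeps the core of compound 1 and changes a single group: fluoro in place of trifluoromethyl on an aromatic carbon. For the measured compounds named here, no measured pair of compounds shows the effect of this exact change, so these data alone cannot say whether the smaller group at that position raises or lowers the read-out. The step from compound 1 to compound 3 is expected to be modest, a number 6.6 percentage points lower from compound 1 to compound 3 (within the scatter), leaning slightly downward but not clearly beyond the scatter. Compound 3 is therefore estimated to give about 55% in this assay, within a range of 35% to 75%.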

Compound 3, a percentage reported as inhibition, at one concentration (the size of the read-out at that concentration, not a potency): 82.8%
Compound 3: the middle estimate sits 27.8 percentage points below what was measured, and the stated range ends below it.
By their numbers in this assay, from the lowest: compound 1; then compound 3; then compound 2.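

This pair isolates a single change at this position: in this assay, fluoro in place of trifluoromethyl on the aromatic carbon gives a number 21.2 percentage points higher from compound 1 to compound 3 (beyond the scatter). The position is therefore not indifferent to the group it carries, and here the group with one heavy atom goes with a stronger effect than the group with four heavy atoms at the one concentration tested. No measurement shown here accounts for the direction or size of this step.

For the compounds shown here, with only two groups compared at this position, it remains open whether an amine or a carboxylic acid there would give a number closer to compound 1 or to compound 3. It is also unknown whether the step would persist at other concentrations, since a single-concentration read-out is not a measure of potency.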